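The compounds below may be only part of what the source reports. "The series", "measured", "known", "first", "only" and "open" are said of these compounds alone.

Working notes on the series. Compound 1 `Nc1scc(CN2CCN(c3ccc([N+](=O)[O-])cc3)CC2)c1C(=O)c1ccc(Cl)cc1` gives 2% in an assay on CHO cells for displacement of a labelled ligand from adenosine receptor A3 (Homo sapiens), read by scintillation counting, with a stated time of 120 min, tested at 10 uM; on this read-out higher numbers stand for more inhibition at the one concentration tested (going by the name of the read-out) and lower numbers for less inhibition. Compound 2 `Nc1scc(CN2CCN(c3cccnc3)CC2)c1C(=O)c1ccc(Cl)cc1` gives 0% in this assay, and compound 3 `Nc1scc(CN2CCN(C3CCCCCC3)CC2)c1C(=O)c1ccc(Cl)cc1` gives 0% in this assay. The three measured steps are a number 2 percentage points lower from compound 1 to compound 2 (within the scatter), a number 2 percentage points lower from compound 1 to compound 3 (within the scatter) and no change at the digits printed from compound 2 to compound 3 (within the scatter); none of them leaves the scatter. Compound 3 therefore stands level with compound 2 at the digits shown, and the whole measured set sits in one narrow band near the bottom of the read-out, so no compound can be set above another.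

Compound 4 `Nc1scc(CN2CCN(c3ccccc3Cl)CC2)c1C(=O)c1ccc(Cl)cc1` is the next member. Relative to compound 3 the change is 2-chlorophenyl in place of cycloheptyl on an amine nitrogen in a ring. For the measured compounds named here, the steps that bear on it are the exchanges at the same amine nitrogen in a ring among compound 1, compound 2 and compound 3, each within the scatter, whether an aromatic or a saturated ring was brought in. A step of no more than the scatter is therefore expected for compound 4, namely a number 1 percentage points higher from compound 3 to compound 4 (within the scatter). The estimate for compound 4 in this assay is 1%, with a range from -8% to 12%.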

Compound 4, a percentage reported as inhibition, at one concentration (the size of the read-out at that concentration, not a potency): 0%
Compound 4: the middle estimate sits 1 percentage points above what was measured; low and high end bracket the measured number.
By their numbers in this assay, from the lowest: compounds 2, 3, 4 and 1 (each within the scatter of the next).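

The 2-chlorophenyl group gives no change at the digits printed from compound 3 to compound 4 (within the scatter), no change at the digits printed from compound 2 to compound 4 (within the scatter) and a number 2 percentage points lower from compound 1 to compound 4 (within the scatter) in this assay. A chlorine-bearing aromatic ring on the amine nitrogen in a ring therefore joins 4-nitrophenyl, pyridin-3-yl and cycloheptyl in the same narrow band, and at this position the four groups cannot be told apart on this read-out. No supporting evidence bears on why the numbers stay together at this position.

The compounds shown leave open whether a carboxylic acid, a primary amine or a longer alkyl chain on this ring nitrogen would give a number outside this band. Also open, going by these compounds, is whether a change elsewhere on the shared core, rather than at this nitrogen, would move the read-out.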